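The compounds below may be only part of what the source reports. "The series", "measured", "known", "first", "only" and "open" are said of these compounds alone.

Compound 1 `CC(=O)OC/C(=C\c1ccc(Cl)cc1Cl)C(=O)c1ccccc1`: 8700 nM
Compound 2 `CCC(/C=C(\COC(C)=O)C(=O)c1ccc(OC)cc1)CC`: 13700 nM
Compound 3 `COc1ccc(C(=O)/C(=C/C2CCCCC2)COC(C)=O)cc1`: 24000 nM

These three compounds have been tested in a functional assay on MCF7 cells (Homo sapiens) for inhibition, read by XTT assay, with a stated time of 48 h; a higher number here means a weaker inhibitor, a lower number a stronger inhibitor. Compound 2 gives 13700 nM, with compound 1 nearest and compound 3 furthest, yet both of those gaps lie within the scatter, so the three numbers cannot be told apart and no order among them is established.

Compound 4 `CCC(/C=C(\CCOC(C)=O)C(=O)c1ccc(OC)cc1)CC` is the next compound to be measured. It differs from compound 2 by acetoxymethyl in place of acetoxy on a saturated chain carbon bound to a double-bonded chain carbon, so the chain carrying the acetoxy group grows by one carbon while everything else stays as in compound 2.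

Among the compounds with values here, only one measured step exists, a 1.8-fold higher number from compound 2 to compound 3 (0.24 log units; within the scatter), and it concerns a different part of the molecule, the group on the double-bonded chain carbon, not the acetoxy-bearing chain. Nothing measured here bears directly on the change from compound 2 to compound 4. Given that the single known step stays within the scatter, the expected step of no change at the digits printed from compound 2 to compound 4 (within the scatter) is also none beyond the scatter, in either direction. Compound 4 is therefore estimated at 13700 nM, within a range from 5000 nM to 38000 nM.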

Compound 4, half-maximal inhibitory concentration: > 100000 nM
Compound 4 gave a limit, no number; the forecaster's own chance of this, stated with the estimate: 5%; middle value at least 7.2-fold (0.86 log units) from the limit.
By their numbers in this assay, from the lowest: compounds 1, 2 and 3 (each within the scatter of the next, the first and the last beyond it). At a limit, above all of these: compound 4.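

In this assay compound 4 gives > 100000 nM, which is a limit of the assay and not a number. Within the data shown here, the change from acetoxymethyl to 2-acetoxyethyl gives an at least 7.2-fold higher number from compound 2 to compound 4 (0.86 log units; beyond the scatter), so the chain carrying the acetoxy group is a place where one modest extension weakens inhibition beyond the scatter, something the only earlier step, a 1.8-fold higher number from compound 2 to compound 3 (0.24 log units; within the scatter), made elsewhere on the molecule, could not reveal. The full size of this step stays unknown, and only its lower bound can be read: the limit of > 100000 nM in this assay, at which 1 of the 4 values shown sits.

The compounds shown leave open whether the chain length alone matters or whether the acetoxy group at its end also plays a part. A hydroxymethyl or methoxymethyl group at this place would be needed to separate the two, and a longer chain would show whether inhibition ever returns.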